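Notes on the nitro sulfone amide series: methyl to hydrogen

This account rests on a few compounds, and the source may have more. Where it says the series, first, only, none or still open, it means among the compounds named here.

Of the compounds shown here, three have been read in an ADME assay on HepG2 cells (Homo sapiens) for cytotoxicity, read by CellTiter-Glo and ATP content, with a stated time of 72 h; a lower number here means that less compound is needed, a higher number that more compound is needed for the effect. Compound 1 `Cc1ccc(N2CCN(C(=O)C3CCN(C(=O)c4ccc(S(C)(=O)=O)c([N+](=O)[O-])c4)CC3)CC2)cc1` gives > 27000 nM there, which is a limit of the assay and not a number. Compound 2 `CN(Cc1cccc(F)c1)C(=O)CNC(=O)c1ccc(S(C)(=O)=O)c([N+](=O)[O-])c1` gives > 27000 nM, again a limit. Compound 3 `CC1CCN(C(=O)CCNC(=O)c2ccc(S(C)(=O)=O)c([N+](=O)[O-])c2)CC1` gives > 27000 nM, also a limit. Compound 1 therefore stands on no number of its own: all three values rest at the limit of > 27000 nM in this assay, at which 3 of the 3 values shown sit, and nothing on what is shown separates compound 1 from compound 2 or compound 3.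

Compound 4 `CS(=O)(=O)c1ccc(C(=O)N2CCC(C(=O)N3CCN(c4ccccc4)CC3)CC2)cc1[N+](=O)[O-]` is not yet measured. It differs from compound 1 by hydrogen in place of methyl on an aromatic carbon: the methyl leaves an aromatic carbon of a six-membered aromatic ring of carbon only, para to a large group, and a hydrogen enters in its place, so that a 4-methylphenyl becomes a phenyl. Going by the values given here, no measured pair differs in one place, so no step size is known from data. The change is small, and every measured value sits at the limit, so across this change the expected step is a step that the limit leaves unreadable from compound 1 to compound 4, none beyond the usual scatter. In this assay compound 4 is estimated at 40000 nM, within 20000 nM to 100000 nM, most likely once more reported only as a limit.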

Compound 4, half-maximal effective concentration: > 27000 nM
Compound 4 was reported as a limit; the forecaster's own chance of this, stated with the estimate: 85%; the middle value does not contradict the limit.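

No step can be read from compound 1 to compound 4, as each value is a limit of the assay and not a number: the limit of > 27000 nM in this assay, at which 4 of the 4 values shown sit.

The compounds shown leave open whether hydrogen in place of methyl, or any other change, alters the half-maximal effective concentration in this assay, since none gives a value inside the readable range.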